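The compounds below may be only part of what the source reports. "The series", "measured", "known", "first", "only" and "open" are said of these compounds alone.

In a functional assay on MDA-MB-231 cells (Homo sapiens) for antiproliferative activity, read by sulforhodamine B assay, with a stated time of 48 h (on this read-out higher numbers stand for weaker inhibition and lower numbers for stronger inhibition), three related compounds have been tested so far. Compound 1, `COc1cc(C(=O)/C=C\Nc2ccc(-c3nc4cc(OC)c(OC)c(OC)c4s3)cc2)c(Br)c(OC)c1OC`, gives 15600 nM. Compound 2, `COc1ccc(C(=O)/C=C\Nc2ccc(-c3nc4cc(OC)c(OC)c(OC)c4s3)cc2C)cc1O`, gives 12400 nM. Compound 3, `COc1cc(OC)c2sc(-c3ccc(N/C=C\C(=O)c4ccc(OC)c(F)c4)cc3)nc2c1`, gives 6700 nM. Compound 1 thus shows the highest number of the three; its nearest neighbour is compound 2, whose number lies within the usual scatter of this kind of measurement, so the two cannot be ranked against each other, while compound 3 lies further off, beyond the scatter, and so inhibits more strongly than compound 1.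

Compound 4, `COc1cc(OC)c2sc(-c3ccc(N/C=C\C(=O)c4cc(OC)c(OC)c(OC)c4Br)cc3)nc2c1`, has not yet been measured. It differs from compound 1 in one place: hydrogen in place of methoxy on an aromatic carbon. Going by the values given here, no pair of measured compounds differs in exactly this way, so the size of this step has no direct precedent here. Compound 3 carries the same core as compound 4, yet it also differs from compound 1 in other parts, so its value alone cannot fix the step. The expectation is a small shift, if any, toward stronger inhibition, not clearly beyond the scatter: the step from compound 1 to compound 4 is estimated at a 1.6-fold lower number from compound 1 to compound 4 (0.19 log units; within the scatter). Compound 4 is expected to give about 10000 nM in this assay, with a likely range from 4000 nM to 25000 nM.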

Compound 4, half-maximal inhibitory concentration: 16100 nM
Estimate against measurement, compound 4: 1.6-fold (0.21 log units) below; the measured number falls inside the stated range.
By their numbers in this assay, from the lowest: compounds 3, 2, 1 and 4 (each within the scatter of the next, the first and the last beyond it).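

In this assay, the swap of this methoxy group for hydrogen on the aromatic carbon ortho to two methoxy groups is a step of a 1.0-fold higher number from compound 1 to compound 4 (0.01 log units; within the scatter). Going by these compounds alone, compound 1 and compound 4 form the first pair here that differs in one place only, so this is the first direct reading of this position, and it shows that this methoxy group can be replaced by hydrogen with no difference that can be told from the usual scatter of the assay. No measurement offered here explains this result.

Within the data shown here, what an amine, a carboxylic acid or a longer chain on this same carbon would do stays open, since methoxy and hydrogen are the only two groups seen there and two groups cannot show how far this tolerance extends. On these data alone, it is also open whether the same swap would give a similar step with a different group on the other end of the molecule, as this single pair speaks only for the bromine-bearing trimethoxyphenyl ketone partner it contains.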